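The source may hold more compounds than are shown below. What is called first, only, known or untested is meant among the compounds shown, and "the series" means these compounds.

This account follows one change made to compound 1 `FC(F)(F)c1ccc2c(c1)nc(-c1cccnc1)n2C1CC1` and read in an assay on V79 cells for inhibition of cytochrome P450 11B1, mitochondrial (Homo sapiens), read by HTRF, with a stated time of 1 h; a higher number here means a weaker inhibitor, a lower number a stronger inhibitor. In this assay compound 1 gives only a limit, > 10000 nM, and no number. Two companions set the scale. Compound 2 `Cc1ccncc1-c1nc2cc(F)c(F)cc2n1C1CC1` gives 723 nM in this assay. Compound 3 `Fc1ccc2nc(-c3cccnc3)n(C3CCC3)c2c1` gives only a limit of > 10000 nM in this assay. Among the compounds with values here, compound 1 thus stands at the limit of > 10000 nM in this assay, at which 2 of the 3 values shown sit, with compound 2 the single measured value that sits clearly lower.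

The change considered is to compound 4 `CS(=O)(=O)c1ccc2c(c1)nc(-c1cccnc1)n2C1CC1`, which differs from compound 1 as follows: methylsulfonyl in place of trifluoromethyl on an aromatic carbon. Within the data shown here, no measured pair of compounds differs in exactly this way, so the size of such a step cannot be read from the data. The starting point of compound 1 is a limit rather than a number. The expectation is accordingly loose. The expected step is an at least 1.2-fold lower number from compound 1 to compound 4 (0.09 log units; that floor lies within the scatter), which is to say no change beyond the usual scatter, with a real chance that only a limit is reported again. Compound 4 is therefore estimated at 8000 nM in this assay, between 2000 nM and 30000 nM.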

Compound 4, half-maximal inhibitory concentration: > 10000 nM
Compound 4 ended at the assay's limit (the forecaster's own chance of this, stated with the estimate: 55%); middle value at least 1.2-fold (0.09 log units) from the limit.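

Compound 1 and compound 4 both give only a limit in this assay and no number, so no step between them can be read: the limit of > 10000 nM in this assay, at which 3 of the 4 values shown sit.

The compounds shown leave open whether trifluoromethyl and methylsulfonyl on this core differ at all in this read-out.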